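Hydroxyphenyl substitution on the triazole nitrogen of a bicyclic lactam

A few compounds are considered here, and "the series" means these few. Any claim that something is new, unique, unknown or untested is made for them only; others in the source may bear on it.

The shared core of this small set is that of compound 1 `Cc1ccccc1-n1cc(CN2C(=O)C[C@@H]3CC[C@@]2(C)C3(C)C)nn1`, which in a functional assay on PANC-1 cells (Homo sapiens) for inhibition, read by MTT assay, with a stated time of 24 h (on this read-out lower numbers stand for stronger inhibition and higher numbers for weaker inhibition), gives 250 nM. Compound 2 `COc1ccc(-n2cc(CN3C(=O)C[C@@H]4CC[C@@]3(C)C4(C)C)nn2)cc1` carries a 4-methoxyphenyl on the aromatic nitrogen and gives 330 nM in this assay. Compound 1 stands on the lower of the two numbers, but the step of a 1.3-fold higher number from compound 1 to compound 2 (0.12 log units; within the scatter) is within the scatter, so no order between the two can be claimed.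

Compound 3 `CC1(C)[C@H]2CC[C@]1(C)N(Cc1cn(-c3cccc(O)c3)nn1)C(=O)C2` has not yet been measured. Relative to compound 1 the change is 3-hydroxyphenyl in place of 2-methylphenyl on an aromatic nitrogen. Going by the values given here, the only measured step that bears on this change is the swap on the same aromatic nitrogen from compound 1 to compound 2, which gave a 1.3-fold higher number from compound 1 to compound 2 (0.12 log units; within the scatter); that single comparison shows one aryl substitution at this position moving the number only within the scatter. Among the compounds with values here, no measured step involves a hydroxyl group, so the data give no guide to the donor it brings.

Compound 3 is therefore expected to sit close to compound 1, at about 350 nM in this assay, within a range of 150 nM to 900 nM; this estimate means a step of a 1.4-fold higher number from compound 1 to compound 3 (0.15 log units; within the scatter).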

Compound 3, half-maximal inhibitory concentration: 280 nM
Beside the measured number, compound 3's estimate is 1.3-fold (0.10 log units) above it; measured number inside the range.
By their numbers in this assay, from the lowest: compounds 1, 3 and 2 (each within the scatter of the next).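

In this assay, 3-hydroxyphenyl in place of 2-methylphenyl on the aromatic nitrogen gives a 1.1-fold higher number from compound 1 to compound 3 (0.05 log units; within the scatter), and 3-hydroxyphenyl in place of 4-methoxyphenyl at the same place gives a 1.2-fold lower number from compound 2 to compound 3 (0.07 log units; within the scatter). The earlier pair had shown only that one aryl exchange at this position stays within the scatter; these steps extend that reading to an aryl group carrying a hydroxyl, since 3-hydroxyphenyl brings a hydrogen-bond donor and a hydrogen-bond acceptor that 2-methylphenyl lacks, and still no step between the three compounds can be read as a difference. Nothing measured here accounts for this result.

All three compounds carry a substituted phenyl on the aromatic nitrogen, so they leave open whether a group of another kind at this place, such as a carboxylic acid or a longer chain ending in an amine, would move the number beyond the scatter. They also share the same core, and so they say nothing about how a change made anywhere else in the molecule would read out in this assay.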